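Losing the phenylsulfamoyl group from compound 2

This account rests on a few compounds, and the source may have more. Where it says the series, first, only, none or still open, it means among the compounds named here.

Compound 1 `CC#C[C@H]1CN(S(=O)(=O)c2ccc(N)nc2)CCN1c1ccc(S(N)(=O)=O)cc1` gives 30 mL.min-1.g-1 in an ADME assay (liver) for metabolic stability, with Liver microsome (Rattus norvegicus) as the target, using microsomes and NADPH, with a stated time of 30 min; a lower number here means slower removal, a higher number faster removal of the compound
Compound 2 `CC#C[C@H]1CN(S(=O)(=O)c2ccc(N)nc2)CCN1c1ccc(S(=O)(=O)Nc2ccccc2)cc1` gives > 399 mL.min-1.g-1 in this assay

Of compound 2 only a limit is known: > 399 mL.min-1.g-1 is no number, and it marks the high end of the values in this assay. Compound 3 `CC#C[C@H]1CN(S(=O)(=O)c2ccc(N)nc2)CCN1c1ccc(C(O)(COC)C(F)(F)F)cc1` has not yet been measured. It differs from compound 2 on an aromatic carbon, para to a large group: a group of 9 heavy atoms (4 carbon, 2 oxygen, 3 fluorine; no ring) in place of a group of 10 heavy atoms (6 carbon, 1 nitrogen, 2 oxygen, 1 sulfur; one six-membered aromatic ring of carbon only), on an aromatic carbon. Among the compounds with values here, one measured step bears on this change. That step, an at least 13-fold higher number from compound 1 to compound 2 (1.12 log units; beyond the scatter), is large and beyond the scatter, and it added the phenyl that compound 3 no longer carries. Within the data shown here, with that step as the only guide, a large move toward lower numbers is expected, though its exact size stays open. The expected change is an at least 4.9-fold lower number from compound 2 to compound 3 (0.69 log units; beyond the scatter) in this assay. For compound 3 the estimated value is 80 mL.min-1.g-1, with an expected range from 25 mL.min-1.g-1 to 250 mL.min-1.g-1.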

Compound 3, intrinsic clearance in microsomes: 93 mL.min-1.g-1
The estimate for compound 3 lay 1.2-fold (0.07 log units) below the measured number; low and high end bracket the measured number.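

Setting the ring-free group of compound 3 in place of the phenylsulfamoyl group on this aromatic carbon gave, in this assay, an at least 4.2-fold lower number from compound 2 to compound 3 (0.63 log units; beyond the scatter), so a group of similar size here need not carry the number of compound 2. The new group still does not match the sulfamoyl group of compound 1, the step being a 3.1-fold higher number from compound 1 to compound 3 (0.49 log units; beyond the scatter), and compound 1 keeps the lowest number of the three. The first step is only a lower bound, since the value of compound 2 is a limit and not a number: the limit of > 399 mL.min-1.g-1 in this assay, at which 1 of the 3 values shown sits.

Which part of the new group, the hydroxyl, the methoxymethyl or the trifluoromethyl, goes with the lower number stays open, since the three occur only together. As far as these compounds go, how a nitrile, an amide or a carboxylic acid at this place would read in this assay also remains open.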